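A Second Methyl on the Shared Core

This account rests on a few compounds, and the source may have more. Where it says the series, first, only, none or still open, it means among the compounds named here.

compound 1 `O=C1CC(c2nc(-c3ccccc3)no2)CN1c1ccccc1` 350 nM
compound 2 `Cc1ccc(N2CC(c3nc(-c4ccccc4)no3)CC2=O)cc1` 384 nM
compound 3 `O=C1CC(c2nc(-c3cccc(Cl)c3)no2)CN1c1ccc(Cl)c(Cl)c1` 460 nM

In an in vitro functional assay on HEK293-A cells for positive allosteric modulation of metabotropic glutamate receptor 5 (Homo sapiens), read by FLIPR and calcium flux (on this read-out lower numbers stand for an effect already at smaller amounts and higher numbers for an effect only at larger amounts of compound), compound 1 gives 350 nM, compound 2 gives 384 nM and compound 3 gives 460 nM. Compound 2 thus sits among three numbers that all lie within the usual scatter of one another. Compound 4 `Cc1ccc(N2CC(c3nc(-c4cccc(C)c4)no3)CC2=O)cc1` is the still unmeasured partner of compound 2, differing only by methyl in place of hydrogen on an aromatic carbon. Among the compounds with values here, the one measured step of the same kind, a 1.1-fold higher number from compound 1 to compound 2 (0.04 log units; within the scatter), put a methyl on the other aromatic ring and stayed within the scatter; compound 3, which carries chloro on the phenyl ring touched here, shows a number close to the others. The step of a 1.0-fold higher number from compound 2 to compound 4 (0.02 log units; within the scatter) is therefore expected to stay within the scatter. Compound 4 is estimated at 400 nM, between 200 nM and 800 nM.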

Compound 4, half-maximal effective concentration: 1300 nM
Beside the measured number, compound 4's estimate is 3.3-fold (0.51 log units) below it; measured number above the stated range.
By their numbers in this assay, from the lowest: compounds 1, 2 and 3 (each within the scatter of the next); then compound 4.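

In this assay the change from phenyl to 3-methylphenyl gives a 3.4-fold higher number from compound 2 to compound 4 (0.53 log units; beyond the scatter) and lies beyond the scatter, so this position on the second phenyl ring responds to a single added methyl. The same replacement on the other aromatic ring, a 1.1-fold higher number from compound 1 to compound 2 (0.04 log units; within the scatter), stays within the scatter, which shows that the outcome of this change depends on the ring that carries it. No measurement shown here accounts for the difference between the two steps.

Going by these compounds, whether a fluoro, methoxy or ethyl group at this place would behave like the methyl remains open. So does the effect of a methyl on the other carbons of this ring.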